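From methoxy to methylsulfonyl: compound 3 to compound 4

This account rests on a few compounds, and the source may have more. Where it says the series, first, only, none or still open, it means among the compounds named here.

Going by the values given here, in a functional assay on the whole organism with Canis familiaris (Canis lupus familiaris) as the target (on this read-out higher numbers stand for an effect only at larger amounts of compound and lower numbers for an effect already at smaller amounts), compound 3 (`COc1ccc(-c2nc3ccc[nH]c-3n2)c(OC)c1`) gives 0.8 mg/kg, the lowest of the three numbers so far. Compound 2 (`Cc1cccc(-c2nc3ccc[nH]c-3n2)c1`) gives 2.8 mg/kg and compound 1 (`CS(=O)(=O)c1ccc(-c2nc3ccc[nH]c-3n2)cc1`) gives 18 mg/kg, both higher than compound 3 by more than the scatter. Compound 4 (`COc1cc(S(C)(=O)=O)ccc1-c1nc2ccc[nH]c-2n1`) carries methylsulfonyl in place of methoxy on an aromatic carbon, meta to a methoxy group: methylsulfonyl in place of methoxy on an aromatic carbon. Among the compounds with values here, no measured pair isolates this change. Within the data shown here, the only guide is compound 1, the one measured compound with methylsulfonyl, at 18 mg/kg, and it has no methoxy. A moderate rise beyond the scatter is therefore expected, with an estimated 3.1-fold higher number from compound 3 to compound 4 (0.49 log units; beyond the scatter). For compound 4 the expected value is 2.5 mg/kg, with an estimated range of 0.7 mg/kg to 9 mg/kg.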

Compound 4, dose for half-maximal effect: 0.4 mg/kg
Beside the measured number, compound 4's estimate is 6.3-fold (0.80 log units) above it, outside the stated range (below it).
By their numbers in this assay, from the lowest: compounds 4 and 3 (each within the scatter of the next); then compound 2; then compound 1.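

In this assay, methylsulfonyl in place of methoxy on this aromatic carbon, meta to a methoxy group, gives no change beyond the scatter (a 2.0-fold lower number from compound 3 to compound 4 (0.30 log units; within the scatter)). The high number of compound 1 therefore does not follow from methylsulfonyl alone: methoxy in place of hydrogen on an aromatic carbon accompanies a large step (a 45-fold lower number from compound 1 to compound 4 (1.65 log units; beyond the scatter)). No evidence bears on the cause of either step.

Open, going by these compounds, is whether an amine or a carboxylic acid on this carbon would keep the number as low. Also open, on these data alone, is whether this methoxy gives a comparable step with other groups on the ring.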